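Lengthening a side chain on a chloro-bearing core

A few compounds are considered here, and "the series" means these few. Any claim that something is new, unique, unknown or untested is made for them only; others in the source may bear on it.

Measured so far:
compound 1, `C[C@H](NC(=O)CN(c1nc(Cl)nc2[nH]cnc12)C1CC1)C(=O)OCc1ccccc1`: 64.3%
compound 2, `O=C(OCc1ccccc1)[C@@H]1CCCN1C(=O)CN(c1nc(Cl)nc2[nH]cnc12)C1CC1`: 34.4%
compound 3, `CC[C@H](C)[C@H](NC(=O)CN(c1ncnc2c1ncn2C1CCCCO1)C1CC1)C(=O)OCc1ccccc1`: 27.4%

The read-out throughout is a functional assay on the whole organism (Tail, strain ICR) with Mus musculus as the target, in the tail flick test, with a stated time of 60 min, at a dose of 25 umol/kg by the oral route; a lower number here means a weaker effect, a higher number a stronger effect of the compound at the dose given. In this assay compound 1 gives 64.3%, the highest of the three numbers. Compound 2 gives 34.4%, and compound 3 gives 27.4%; both fall well below compound 1, beyond the usual scatter of the test.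

Compound 4, `CC[C@H](C)[C@H](NC(=O)CN(c1nc(Cl)nc2[nH]cnc12)C1CC1)C(=O)OCc1ccccc1`, has not yet been measured. It differs from compound 1 in a single place: sec-butyl in place of methyl on a saturated chain carbon bound to an amide-type nitrogen and a carbonyl carbon. Compound 3 carries the same sec-butyl group at that place, but its core is not the core of compound 1, so its value does not show this step directly. Going by the values given here, no step between measured compounds with the same core is available, and the change itself is a small one in size, adding a few carbons on the chain. The expectation is a modest drop, in the direction from compound 1 downward, though a result within the scatter of compound 1 cannot be ruled out. Compound 4 is expected to give 47% in this assay, most likely between 22% and 72%, which means an estimated step of a number 17.3 percentage points lower from compound 1 to compound 4 (beyond the scatter).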

Compound 4, a percentage reported as activity, at one dose (the size of the read-out at that dose, not a potency): 40.6%
The estimate for compound 4 lay 6.4 percentage points above the measured number; the range from low to high includes it.
By their numbers in this assay, from the lowest: compounds 3, 2 and 4 (each within the scatter of the next, the first and the last beyond it); then compound 1.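

With the core of compound 1 held fixed, this position can now be read directly: in this assay, sec-butyl in place of methyl on a saturated chain carbon bound to an amide-type nitrogen and a carbonyl carbon gives a number 23.7 percentage points lower from compound 1 to compound 4 (beyond the scatter) on this single change. The position is therefore not indifferent to what sits there, although the larger group reduces the effect without abolishing it, since compound 4 still gives 40.6% at the dose tested. Nothing measured alongside these compounds says why the number falls.

Going by these compounds, with only methyl and sec-butyl readable at this place on this core, it remains open whether ethyl or isopropyl would keep the number of compound 1 or lose as much as sec-butyl, and how a chain carrying an amine or a carboxylic acid would behave. The sec-butyl group also brings a defined stereocentre, so its other stereoisomers remain an open question, and a reading at one dose in this assay gives the size of the effect at that dose rather than a potency.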